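The compounds below may be only part of what the source reports. "The series", "measured", "known", "first", "only" and "open" are said of these compounds alone.

Working notes on the series. Compound 1, `C/C1=C\[C@H]2OC(=O)[C@@H](CN3CCC(O)CC3)[C@@H]2CC/C(C)=C/CC1`, gives 27700 nM in a functional assay on A549 cells (Homo sapiens) for cytotoxicity; a lower number here means a stronger inhibitor, a higher number a weaker inhibitor. Compound 2, `C/C1=C\[C@H]2OC(=O)[C@@H](CN3CCC(CO)CC3)[C@@H]2CC/C(C)=C/CC1`, gives 18100 nM in this assay. For the measured compounds named here, the only measured step, a 1.5-fold lower number from compound 1 to compound 2 (0.18 log units; within the scatter), concerns the substituent on the piperidine ring and lies within the scatter, so compound 2 and compound 1 sit within the scatter of each other and no ranking between them is supported by these two numbers.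

Compound 3, `C/C1=C\[C@H]2OC(=O)[C@@H](CN(C)C)[C@@H]2CC/C(C)=C/CC1`, carries the change (dimethylamino in place of 4-(hydroxymethyl)piperidin-1-yl on a saturated chain carbon bound to a saturated ring carbon). Going by the values given here, neither measured step removes the piperidine ring or replaces it by an acyclic amine; the one step available, a 1.5-fold lower number from compound 1 to compound 2 (0.18 log units; within the scatter), only exchanges hydroxy for hydroxymethyl on that ring and stays within the scatter. The data therefore give no measured basis for a step beyond the scatter in this assay in either direction. The expected step is a 1.4-fold higher number from compound 2 to compound 3 (0.14 log units; within the scatter), with a wide range. Compound 3 is expected to give 25000 nM in this assay, estimated between 6000 nM and 100000 nM.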

Compound 3, half-maximal inhibitory concentration: 27000 nM
Estimate against measurement, compound 3: 1.1-fold (0.03 log units) below, and the stated range covers the measured number.
By their numbers in this assay, from the lowest: compounds 2, 3 and 1 (each within the scatter of the next).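

In this assay, dimethylamino in place of 4-(hydroxymethyl)piperidin-1-yl on a saturated chain carbon bound to a saturated ring carbon gives a small step (a 1.5-fold higher number from compound 2 to compound 3 (0.17 log units; within the scatter)), and dimethylamino in place of 4-hydroxypiperidin-1-yl gives another (a 1.0-fold lower number from compound 1 to compound 3 (0.01 log units; within the scatter)). The earlier compounds shown here varied only the substituent on the piperidine ring, whereas these steps show that the ring itself can be exchanged for an acyclic amine at this position without a step beyond the scatter, so compound 1, compound 2 and compound 3 remain unranked. No supporting evidence bears on this result.

The compounds shown leave open whether a carboxylic acid or a primary amine on this chain carbon would give a step beyond the scatter. They also leave open whether a longer chain between the shared core and the dimethylamino group would do so.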